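A few compounds are considered here, and "the series" means these few. Any claim that something is new, unique, unknown or untested is made for them only; others in the source may bear on it.

Of the compounds shown here, three have been measured in an ADME assay on microsomes from liver (Homo sapiens) for metabolic stability; a lower number here means slower removal, a higher number faster removal of the compound. Compound 1 `COc1cc(C(=O)N2CCCC2)ccc1-c1ccnc2[nH]c(C3CCOCC3)cc12` gives 74 uL/min. Compound 2 `CC(C)n1cc(-c2ccnc3[nH]c(C4CCN(CC(=O)N5CCCC5)CC4)cc23)ccc1=O` gives 45 uL/min, and compound 3 `CN(C)C(=O)CN1CCC(c2cc3c(-c4ccc(=O)n(CC5CCOCC5)c4)ccnc3[nH]2)CC1` gives 20 uL/min. Compound 2 sits in the middle of these three numbers: its gap to compound 1 lies within the scatter, while its gap to compound 3 lies beyond it.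

Compound 4 `CNC(=O)CN1CCC(c2cc3c(-c4ccc(=O)n(C(C)C)c4)ccnc3[nH]2)CC1` has not yet been measured. It differs from compound 2 in one place: methylamino in place of pyrrolidin-1-yl on a carbonyl carbon. Among the measured compounds shown here, no measured pair shows this change, so the step can only be guessed. The expected step is a 1.4-fold lower number from compound 2 to compound 4 (0.15 log units; within the scatter), small and downward, not clearly beyond the scatter. Compound 4 is therefore estimated at 32 uL/min, with a range from 15 uL/min to 65 uL/min.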

Compound 4, intrinsic clearance in a liver preparation (reported as CLH), per the amount of preparation that the assay uses: 8.6 uL/min
Compound 4: middle estimate off by 3.7-fold (0.57 log units), on the high side, and the stated range ends above it.
By their numbers in this assay, from the lowest: compound 4; then compound 3; then compounds 2 and 1 (each within the scatter of the next).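

In this assay, among the compounds shown here, the group on this carbonyl carbon matters more than the earlier compounds could show: methylamino in place of pyrrolidin-1-yl gives a 5.2-fold lower number from compound 2 to compound 4 (0.72 log units; beyond the scatter). This one change removes the ring and adds the amide hydrogen, and it leaves the rest of the molecule untouched. Nothing measured here explains the step.

Going by these compounds, whether the ring's loss, the smaller group or the amide hydrogen drives the step remains open. Ethylamino or plain amino at this place could help separate these possibilities.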